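A few compounds are considered here, and "the series" means these few. Any claim that something is new, unique, unknown or untested is made for them only; others in the source may bear on it.

Compound 1 `CCN(c1cccc(-c2ccccc2)c1)c1ccc(C#N)c(Cl)c1` enters this account without a number. In a functional assay on PC-3 cells (Homo sapiens) for antiproliferative activity, read by CCK-8 assay, with a stated time of 6 days (a lower number here means a stronger inhibitor, a higher number a weaker inhibitor), compound 1 is recorded as "not determined" (no result reported). Its close relative compound 2 `CCN(c1ccc(C#N)c(Cl)c1)c1cc(-c2ccccc2)ccc1C` is in the same position, recorded as "not determined" (no result reported). Among the compounds with values here, the only reading in the set comes from compound 3 `CCN(c1ccc(C#N)c(Cl)c1)c1cc(-c2cccs2)ccc1C`, which gives > 30000 nM, and this is a limit of the assay rather than a number. Compound 1 therefore has no measured standing of its own, and the one neighbouring result is a limit.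

The next compound, compound 4 `CCN(c1cccc(-c2cncnc2)c1)c1ccc(C#N)c(Cl)c1`, carries pyrimidin-5-yl in place of phenyl on an aromatic carbon, and the change is pyrimidin-5-yl in place of phenyl on an aromatic carbon. With no number for compound 1, the size of this step in this assay cannot be read from the data, and no strong gain in either direction is expected. The expectation of weak activity rests on compound 3 and its limit of > 30000 nM. For compound 4 the estimated value is 25000 nM, with an expected range from 8000 nM to 45000 nM.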

Compound 4, half-maximal inhibitory concentration: > 30000 nM
Compound 4 ended at the assay's limit; the forecaster's own chance of this, stated with the estimate: 65%; at least 1.2-fold (0.07 log units) between middle value and limit.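

Within the data shown here, no step from compound 1 to compound 4 can be read: compound 1 carries no number in this assay. Compound 4 gives > 30000 nM, which is a limit of the assay and not a number. The compounds shown leave open whether any member of this series reaches a measurable potency.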